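This account rests on a few compounds, and the source may have more. Where it says the series, first, only, none or still open, it means among the compounds named here.

Series notes on a shared core bearing a 3,4,5-trimethoxyphenyl group and an enone arm. Compound 3 `COc1cc(-c2cc(/C=C/C(=O)c3ccc(C)c(C)c3)nc3cc(-c4ccccc4)nn23)cc(OC)c1OC` gives 72500 nM in an ADME assay on HEK293 cells (Homo sapiens) for antiproliferative activity, read by MTT assay, with a stated time of 24 h; a higher number here means a weaker inhibitor, a lower number a stronger inhibitor. Compound 1 `COc1ccc(-c2cc(C(=O)/C=C/c3ccc(C)cc3)nc3cc(-c4ccccc4)nn23)cc1OC` gives 57400 nM in this assay, and the gap between compound 1 and compound 3 lies within the scatter, so no order can be read between the two. Compound 2 `COc1cc(-c2cc(/C=C/C(=O)c3ccccc3)nc3cc(-c4ccccc4)nn23)cc(OC)c1OC` reaches only a limit in this assay, >= 100000 nM. Going by the values given here, the one measured step, an at least 1.3-fold lower number from compound 2 to compound 3 (0.13 log units; that floor lies within the scatter), rests on the limit of >= 100000 nM in this assay, at which 1 of the 3 values shown sits, and cannot be set larger than its floor.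

Compound 4 `COc1cc(-c2cc(C(=O)/C=C/c3ccc(C)cc3)nc3cc(-c4ccccc4)nn23)cc(OC)c1OC` is not yet measured. Against compound 3 the change is (2-(4-methylphenyl)ethenyl)carbonyl in place of 2-((3,4-dimethylphenyl)carbonyl)ethenyl on an aromatic carbon. Among the compounds with values here, no measured step concerns this change: the step from compound 2 to compound 3 alters only the methyl pattern of the phenyl on the carbonyl carbon, and no step is given between compound 1 and compound 3. The same (2-(4-methylphenyl)ethenyl)carbonyl arm as in compound 4 is carried by compound 1, which gives 57400 nM, within the scatter of compound 3. Hence no step beyond the scatter is expected, a 1.2-fold lower number from compound 3 to compound 4 (0.08 log units; within the scatter). Compound 4 is estimated at 60000 nM in this assay, within 25000 nM to 150000 nM.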

Compound 4, half-maximal inhibitory concentration: 56100 nM
Compound 4: the middle estimate sits 1.1-fold (0.03 log units) above what was measured; measured number inside the range.
By their numbers in this assay, from the lowest: compounds 4, 1 and 3 (each within the scatter of the next). At a limit, above all of these: compound 2.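

Going by these compounds alone, on the 3,4,5-trimethoxyphenyl core, the first direct comparison at this aromatic carbon, (2-(4-methylphenyl)ethenyl)carbonyl in place of 2-((3,4-dimethylphenyl)carbonyl)ethenyl, gives a 1.3-fold lower number from compound 3 to compound 4 (0.11 log units; within the scatter) in this assay, so this exchange of arms does not separate the two compounds. The added methoxy on an aromatic carbon, with that arm held constant, gives a 1.0-fold lower number from compound 1 to compound 4 (0.01 log units; within the scatter), so this single change also leaves no readable difference. The step involving the 2-benzoylethenyl arm, an at least 1.7-fold lower number from compound 2 to compound 4 (0.25 log units; that floor lies within the scatter), gives only a floor and no exact size, and it rests on a limit of the assay: the limit of >= 100000 nM in this assay, at which 1 of the 4 values shown sits.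

The exchange between compound 3 and compound 4 changes both the place of the carbonyl in the arm and the methyl pattern on its phenyl ring, so the shown compounds do not separate these two features. Also open, going by these compounds, is whether an amine or a carboxylic acid on that phenyl ring, or a longer chain in place of the ethenyl unit, would give a step beyond the scatter from compound 4.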